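A few compounds are considered here, and "the series" means these few. Any claim that something is new, unique, unknown or untested is made for them only; others in the source may bear on it.

Working notes on the series. Compound 1 `Cn1c(=O)c2nc(-c3ccc(Br)cc3)[nH]c2n(C)c1=O` carries a bromo group on the phenyl ring of the shared core. In an assay for binding affinity to adenosine receptor A1 (Bos taurus) (on this read-out higher numbers stand for weaker inhibition and lower numbers for stronger inhibition), compound 1 gives 0.75 nM, the lowest number of the three measured compounds, and its gap to each of the other two lies beyond the usual scatter. Compound 2 `Cn1c(=O)c2nc(-c3cccc(N)c3)[nH]c2n(C)c1=O` gives 10 nM in this assay, and compound 3 `Cn1c(=O)c2nc(-c3cccc(O)c3)[nH]c2n(C)c1=O` gives 6 nM. Going by the values given here, the only single-point step measured so far is a 1.7-fold lower number from compound 2 to compound 3 (0.22 log units; within the scatter), which stays within the scatter.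

Compound 4 `CCOc1ccc(-c2nc3c(=O)n(C)c(=O)n(C)c3[nH]2)cc1` is the next compound to be measured. Relative to compound 1 the change is ethoxy in place of bromo on an aromatic carbon. Among the compounds with values here, no measured step covers this change: the one step in hand concerns other groups, and compounds 2 and 3 differ from compound 1 both in the group carried and in where it sits, so they do not isolate the exchange of bromo for ethoxy. The expectation is therefore uncertain, with a moderate rise in the number considered the more likely outcome, of a size that may just exceed the scatter. Compound 4 is expected to give about 3 nM in this assay, within a range from 0.8 nM to 12 nM. This corresponds to an expected 4.0-fold higher number from compound 1 to compound 4 (0.60 log units; beyond the scatter).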

Compound 4, half-maximal inhibitory concentration: 2 nM
Beside the measured number, compound 4's estimate is 1.5-fold (0.18 log units) above it, within the range that was stated.
By their numbers in this assay, from the lowest: compound 1; then compound 4; then compounds 3 and 2 (each within the scatter of the next).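

In this assay, going by these compounds alone, ethoxy in place of bromo on an aromatic carbon, para to a large group, gives a 2.7-fold higher number from compound 1 to compound 4 (0.43 log units; beyond the scatter), the first measured step at this position. The step is modest but beyond the scatter, so a bromine atom can be exchanged here for a chain of three heavy atoms with one hydrogen-bond acceptor at only a modest rise in the number. Nothing available explains the direction or size of this step.

As far as these compounds go, with only bromo and ethoxy compared at this position, it remains open how the number would respond to an amine, a carboxylic acid or a longer alkoxy chain there. From the compounds shown here alone, it also remains open whether ethoxy would give a similar step at the ring position carrying the amino group in compound 2 and the hydroxy group in compound 3.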